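The source may report more compounds than this note shows. Statements on the series, on what has been measured and on what is new or still open speak of the compounds shown alone.

Measured compounds:
compound 1, `O=C(O)c1cc(N2C(=O)C3=C(CCCC3)C2=O)c(F)cc1Cl`, 3160 nM
compound 2, `O=C(O)c1cc(N2C(=O)C3=C(CCCC3)C2=O)ccc1Cl`, > 100000 nM
compound 3, `CC(C)OC(=O)c1cc(N2C(=O)C3=C(CCCC3)C2=O)ccc1Cl`, 182 nM

In a functional assay on the whole organism with Scenedesmus acutus as the target, with a stated time of 20 h (on this read-out lower numbers stand for stronger inhibition and higher numbers for weaker inhibition), compound 1 gives 3160 nM, the higher of the two numbers shown, with compound 3 at 182 nM. The value for compound 2 is a limit of this assay rather than a number (the limit of > 100000 nM in this assay, at which 1 of the 3 values shown sits).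

Compound 4, `CC(C)COC(=O)c1cc(N2C(=O)C3=C(CCCC3)C2=O)c(F)cc1Cl`, has not been measured. It differs from compound 1 in one place: isobutyl in place of hydrogen on an oxygen next to a carbonyl group. Going by the values given here, two measured steps touch this change. The step from compound 2 to compound 3 shows what an ester in place of the acid does on this core: an at least 540-fold lower number from compound 2 to compound 3 (2.73 log units; beyond the scatter). The step of an at least 31-fold higher number from compound 1 to compound 2 (1.50 log units; beyond the scatter) shows that compound 1 already carries the fluoro that compound 3 lacks, so compound 4 starts from a lower number than compound 2 did.

Compound 4 is therefore expected to sit well below compound 1 in this assay, with an estimated step of a 160-fold lower number from compound 1 to compound 4 (2.20 log units; beyond the scatter). The estimate for compound 4 is 20 nM, expected to fall between 3 nM and 150 nM.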

Compound 4, half-maximal inhibitory concentration: 407 nM
For compound 4 the middle estimate is 20-fold (1.31 log units) below the measured one; the measured number lies above the stated range.
By their numbers in this assay, from the lowest: compound 3; then compound 4; then compound 1. At a limit, above all of these: compound 2.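

In this assay, the change from carboxy to isobutoxycarbonyl on the fluoro-bearing compound gives a step with a full, readable size: a 7.8-fold lower number from compound 1 to compound 4 (0.89 log units; beyond the scatter). Going by these compounds alone, the earlier step from acid to ester, an at least 540-fold lower number from compound 2 to compound 3 (2.73 log units; beyond the scatter), could not give such a size, and it started from compound 2, whose value is a limit and not a number: the limit of > 100000 nM in this assay, at which 1 of the 4 values shown sits. On the evidence of these two pairs, an ester in place of the acid lowers the number both with and without the fluoro, and the one pair with two true numbers shows a modest step.

The compounds shown hold the isopropyl ester only without the fluoro and the isobutyl ester only with it, so the two ester groups cannot be set against each other, and what the fluoro does within an ester stays open. From the compounds shown here alone, how a methyl ester, a longer alkyl chain on the same oxygen, or a primary amide in place of the carboxy group would read in this assay also stays open.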